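Moving the Methoxy Group Around the Ring

A few compounds are considered here, and "the series" means these few. Any claim that something is new, unique, unknown or untested is made for them only; others in the source may bear on it.

Of the compounds shown here, two sharing one core have been measured in an ADME assay on isolated protein for inhibition of Amine oxidase [flavin-containing] B (Homo sapiens); on this read-out lower numbers stand for stronger inhibition and higher numbers for weaker inhibition. Compound 1 `C#CCNC1CCc2c(SCCc3ccc(Cl)cc3)cccc21` gives 920 nM. Going by the values given here, compound 2 `C#CCNC1CCc2c(SCCc3cccc(OC)c3)cccc21` gives 3820 nM, the higher of the two numbers and therefore the weaker inhibitor of the pair; the only step measured so far, a 4.2-fold higher number from compound 1 to compound 2 (0.62 log units; beyond the scatter), separates them. Compound 3 `C#CCNC1CCc2c(SCCc3ccc(OC)cc3)cccc21` differs from compound 2 only by 4-methoxyphenyl in place of 3-methoxyphenyl on a saturated chain carbon, two bonds along the chain from a sulfur. Among the compounds with values here, no measured step moves a methoxy group from one ring position to another, so the single step at hand bears on this change only indirectly, since it swapped the group as well as its position. On that thin basis no step beyond the scatter is expected. For compound 3 the estimated change is a 1.4-fold lower number from compound 2 to compound 3 (0.13 log units; within the scatter), which would place compound 3 at 2800 nM, with a range from 1000 nM to 8000 nM. That expectation now waits on the measurement.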

Compound 3, half-maximal inhibitory concentration: 4590 nM
Compound 3: middle estimate off by 1.6-fold (0.21 log units), on the low side; the range from low to high includes it.
By their numbers in this assay, from the lowest: compound 1; then compounds 2 and 3 (each within the scatter of the next).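

In this assay, moving the methoxy group from 3-methoxyphenyl to 4-methoxyphenyl gives a 1.2-fold higher number from compound 2 to compound 3 (0.08 log units; within the scatter), so among these compounds its ring position makes no difference that can be told from the scatter. The earlier step changed both the group and its position, whereas the comparison of 4-chlorophenyl with 4-methoxyphenyl changes only the group, with methoxy in place of chloro giving a 5.0-fold higher number from compound 1 to compound 3 (0.70 log units; beyond the scatter), a gap beyond the scatter that goes with the group itself. Nothing available explains why chloro and methoxy differ here.

The compounds shown leave open whether chloro would behave like methoxy and show no such insensitivity to position, as a 3-chlorophenyl group would reveal. They also leave open how other groups in that place, such as fluoro or an amine, would compare with chloro.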